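Ester replaces isocyanide on the chain carbon of compound 2

This account rests on a few compounds, and the source may have more. Where it says the series, first, only, none or still open, it means among the compounds named here.

Three members of the series have numbers in a functional assay on the whole organism with Rattus norvegicus as the target, with a stated time of 4 h, at a dose of 40 mg/kg by the intraperitoneal route; on this read-out higher numbers stand for more inhibition at the one dose given (going by the name of the read-out) and lower numbers for less inhibition. Compound 1 `Cc1cn2cccc(OCc3ccccc3)c2n1` gives 62%, compound 2 `[C-]#[N+]Cc1c(C)nc2c(OCc3ccccc3)cccn12` gives 96%, and compound 3 `Cc1nc2c(OCc3ccccc3)cccn2c1Br` gives 26%. Compound 2 stands highest of the three: the step of a number 34 percentage points higher from compound 1 to compound 2 (beyond the scatter) and the step of a number 70 percentage points lower from compound 2 to compound 3 (beyond the scatter) both lie beyond the scatter, as does a number 36 percentage points lower from compound 1 to compound 3 (beyond the scatter).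

Compound 4 `Cc1nc2c(OCc3ccccc3)cccn2c1COC(=O)C(C)(C)C` differs from compound 2 at one place: a group of 7 heavy atoms (5 carbon, 2 oxygen; no ring) in place of a group of 2 heavy atoms (1 carbon, 1 nitrogen; no ring), on a saturated chain carbon bound to an aromatic carbon. Going by the values given here, no measured step exchanges one group for another on a saturated chain carbon bound to an aromatic carbon, so none bears on it directly. The steps that exist show that what sits on that aromatic carbon moves this assay strongly, in both directions, but the chain carbon is kept in compound 4, and the data give no direction for swapping its terminal group. A step of either sign, possibly beyond the scatter, is plausible; a modest loss is taken as the middle case. Compound 4 is therefore expected to give 70%, within a range from 40% to 95%. This estimate corresponds to an expected step of a number 26 percentage points lower from compound 2 to compound 4 (beyond the scatter).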

Compound 4, a percentage reported as inhibition, in the whole organism at one dose (the size of the read-out at that dose, not a potency): 48%
The estimate for compound 4 lay 22 percentage points above the measured number; low and high end bracket the measured number.
By their numbers in this assay, from the lowest: compound 3; then compound 4; then compound 1; then compound 2.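

Among the compounds shown, this is the only exchange of one group for another on a saturated chain carbon bound to an aromatic carbon, and in this assay ((tert-butyl)carbonyl)oxy in place of the isocyanide gives a number 48 percentage points lower from compound 2 to compound 4 (beyond the scatter), so keeping the chain carbon alone does not keep the number of compound 2. Set against the other groups on the aromatic carbon, (((tert-butyl)carbonyl)oxy)methyl gives a number 22 percentage points higher from compound 3 to compound 4 (beyond the scatter) and a number 14 percentage points lower from compound 1 to compound 4 (beyond the scatter), which places this chain group above bromo but below hydrogen in this series. Nothing available explains the size or direction of these steps.

From the compounds shown here alone, whether a hydroxy group, an amine or a nitrile on the same chain carbon would stay nearer to compound 2 remains open. Also open, going by these compounds, is whether a longer chain in that place would move the number in either direction.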